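Swapping the Ring on a Sulfur

A few compounds are considered here, and "the series" means these few. Any claim that something is new, unique, unknown or untested is made for them only; others in the source may bear on it.

In a functional assay on MGC-803 cells (Homo sapiens) for inhibition, read by MTT assay, with a stated time of 72 h (on this read-out higher numbers stand for weaker inhibition and lower numbers for stronger inhibition), compound 1 `Cc1csc(Sc2cc(C(F)(F)F)nc(SCc3ccc(C(F)(F)F)cc3)n2)n1` gives 21300 nM and compound 2 `FC(F)(F)c1ccc(CSc2nc(Sc3ncccn3)cc(C(F)(F)F)n2)cc1` gives 28600 nM as measured values. Compound 3 `FC(F)(F)c1ccc(CSc2nc(Sc3ccccn3)cc(C(F)(F)F)n2)cc1` reads > 50000 nM, which is a limit and not a number.

Compound 4 `FC(F)(F)c1ccc(CSc2nc(Sc3nnnn3-c3ccccc3)cc(C(F)(F)F)n2)cc1` has not been measured. It carries 1-phenyl-1H-tetrazol-5-yl in place of pyridin-2-yl on a sulfur.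

For the measured compounds named here, the earlier swaps on that sulfur are the only guide. They gave a 1.3-fold higher number from compound 1 to compound 2 (0.13 log units; within the scatter) and an at least 2.3-fold higher number from compound 1 to compound 3 (0.37 log units; beyond the scatter) as well as an at least 1.7-fold higher number from compound 2 to compound 3 (0.24 log units; that floor lies within the scatter), and the two steps to compound 3 are only floors. None of them tests a tetrazole, so the guide is loose. Compound 1 at 21300 nM shows that a different ring at this place can give a measurable value, so a modest move towards a lower number is expected. The estimated size of that move is an at least 1.5-fold lower number from compound 3 to compound 4 (0.19 log units; that floor lies within the scatter), and the limit may well be met again. For compound 4 the estimate is 32000 nM, with an expected range from 14000 nM to 70000 nM.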

Compound 4, half-maximal inhibitory concentration: 12400 nM
Compound 4: the middle estimate sits 2.6-fold (0.41 log units) above what was measured; the measured number lies below the stated range.
By their numbers in this assay, from the lowest: compounds 4, 1 and 2 (each within the scatter of the next, the first and the last beyond it). At a limit, above all of these: compound 3.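

Compound 4 shows that this sulfur can carry 1-phenyl-1H-tetrazol-5-yl, a group with two aromatic rings, and still give a measured value, with an at least 4.0-fold lower number from compound 3 to compound 4 (0.60 log units; beyond the scatter) and a 2.3-fold lower number from compound 2 to compound 4 (0.36 log units; beyond the scatter). Set against 4-methyl-1,3-thiazol-2-yl, the change gives a 1.7-fold lower number from compound 1 to compound 4 (0.23 log units; within the scatter), so that pair cannot be told apart. The step from the pyridin-2-yl compound is only a floor, because compound 3 stands at a limit and not at a number: the limit of > 50000 nM in this assay, at which 1 of the 4 values shown sits.

As far as these compounds go, whether the tetrazole ring or its phenyl ring matters more stays open, and 1-methyl-1H-tetrazol-5-yl on the same sulfur would separate the two. From the compounds shown here alone, how an open chain such as a simple ethyl group or a ring-free amine-bearing chain would read at this place also stays open.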